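Piperazine acetamides on the shared core: working notes

This account rests on a few compounds, and the source may have more. Where it says the series, first, only, none or still open, it means among the compounds named here.

Measured in a functional assay on HT-29 cells (Homo sapiens) for cytotoxicity, read by MTT assay, with a stated time of 24 h, tested at 1.6 ug/mL (on this read-out higher numbers stand for a stronger effect at the one concentration tested and lower numbers for a weaker effect), so far:
compound 1 `Cn1c(-c2ccc(NC(=O)CSc3nc4cc(Cl)ccc4o3)cc2)nc(-c2ccccc2)c1-c1ccccc1` gives 17.4%
compound 2 `CCN1CCN(CC(=O)Nc2ccc(-c3nc(-c4ccccc4)c(-c4ccccc4)n3C)cc2)CC1` gives 13.9%
compound 3 `CN(C)/C=C/N1CCN(CC(=O)Nc2ccc(-c3nc(-c4ccccc4)c(-c4ccccc4)n3C)cc2)CC1` gives 8%

Among the measured compounds shown here, compound 3 carries the smallest of the three numbers, but its gaps to the others, a number 5.9 percentage points lower from compound 2 to compound 3 (within the scatter) and a number 9.4 percentage points lower from compound 1 to compound 3 (within the scatter), are both within the scatter, so no compound can be called weaker or stronger than another here. The full exchange of the (5-chloro-1,3-benzoxazol-2-yl)sulfanyl group for a piperazine, a number 3.5 percentage points lower from compound 1 to compound 2 (within the scatter), likewise stays within the scatter.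

Compound 4 is `Cn1c(-c2ccc(NC(=O)CN3CCN(Cc4ccccc4)CC3)cc2)nc(-c2ccccc2)c1-c1ccccc1`. Its difference from compound 3 is benzyl in place of 2-(dimethylamino)ethenyl on an amine nitrogen in a ring. The step that bears most directly on it is the change of the group on the same ring nitrogen, a number 5.9 percentage points lower from compound 2 to compound 3 (within the scatter), and the two replacements of the whole side group from compound 1 are of the same kind. For the measured compounds named here, all three steps are within the scatter, and nothing among the measured compounds suggests that a different group on the ring nitrogen moves the read-out beyond it. The expectation is therefore a step of a number 4 percentage points higher from compound 3 to compound 4 (within the scatter) in this assay, that is none beyond the scatter.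

Compound 4 is estimated at 12%, with a range of 3% to 24%.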

Compound 4, a percentage reported as activity, at one concentration (the size of the read-out at that concentration, not a potency): 26%
Compound 4: the middle estimate sits 14 percentage points below what was measured; the whole stated range lies below it.
By their numbers in this assay, from the lowest: compounds 3, 2, 1 and 4 (each within the scatter of the next, the first and the last beyond it).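

Among the compounds shown here, on the amine nitrogen in the ring, the group carried there can move the read-out in this assay beyond the scatter, which the earlier steps did not show: the change to benzyl gives a number 18 percentage points higher from compound 3 to compound 4 (beyond the scatter) and, with the ethyl compound as the reference, a number 12.1 percentage points higher from compound 2 to compound 4 (beyond the scatter) in this small set. The second step is the narrower of the two, since phenyl in place of methyl on a saturated chain carbon bound to an amine nitrogen in a ring is the only difference, so the six-membered aromatic ring of carbon only travels with the higher number among compounds 2, 3 and 4, while the claim rests on these three compounds alone. No measured evidence on the compounds bears on why this change goes with a higher number.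

From the compounds shown here alone, whether the aromatic ring itself matters or only the carbon count of the group stays open, and a cyclohexylmethyl group on the same ring nitrogen would separate the two. A 2-phenylethyl group would show whether the longer chain to the phenyl ring keeps the step, and a read-out at one concentration gives no potency for any of these compounds.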